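The compounds below may be only part of what the source reports. "The series", "measured", "known", "first", "only" and "open" are said of these compounds alone.

Compounds measured in an ADME assay on the whole organism (Rattus norvegicus, strain Sprague-Dawley) for pharmacokinetics, read by LC-MS, with a stated time of 30 min; on this read-out higher numbers stand for wider distribution into tissues and lower numbers for narrower distribution:
- compound 1, `N#Cc1ccc(O[C@H]2CN(S(=O)(=O)c3ccc(C(F)(F)F)cc3)C[C@@]2(O)CO)cc1F`: 180 L/kg
- compound 2, `N#Cc1ccc(O[C@H]2CN(S(=O)(=O)c3ccc(C(F)(F)F)nc3)C[C@@]2(O)CO)cc1F`: 28 L/kg
- compound 3, `N#Cc1ccc(O[C@H]2CN(S(=O)(=O)c3ccc(Cl)cn3)C[C@@]2(O)CN)cc1F`: 47 L/kg

Compound 2 gives the lowest of the three numbers in this assay. Its nearest neighbour is compound 3, whose value stands within the scatter of that of compound 2, so the two cannot be ordered; compound 1 stands further away, beyond the scatter.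

Compound 4, `N#Cc1ccc(O[C@H]2CN(S(=O)(=O)c3ccccc3C#N)C[C@@]2(O)CO)cc1F`, has not been measured. It differs from compound 2 in one place: 2-cyanophenyl in place of 6-(trifluoromethyl)pyridin-3-yl on a sulfonyl sulfur.

Among the compounds with values here, one measured step bears on this change, since it also swaps the aromatic ring on the sulfonyl sulfur: a 6.4-fold lower number from compound 1 to compound 2 (0.81 log units; beyond the scatter). There, a carbon-only ring gave way to a ring holding one nitrogen and the number fell. Within the data shown here, compound 4 goes back to a carbon-only ring, though one carrying a nitrile rather than a trifluoromethyl group, and no measured pair shows the effect of that nitrile. The step is therefore expected to run upward, but with less confidence and smaller size than the step from compound 1 to compound 2. The expected step is a 2.0-fold higher number from compound 2 to compound 4 (0.29 log units; within the scatter).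

Compound 4 is thus estimated at 55 L/kg in this assay, within a range of 20 L/kg to 150 L/kg.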

Compound 4, volume of distribution at steady state: 4.6 L/kg
For compound 4 the middle estimate is 12-fold (1.08 log units) above the measured one, outside the stated range (below it).
By their numbers in this assay, from the lowest: compound 4; then compounds 2 and 3 (each within the scatter of the next); then compound 1.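

In this assay, 2-cyanophenyl in place of 6-(trifluoromethyl)pyridin-3-yl on a sulfonyl sulfur gives a 6.1-fold lower number from compound 2 to compound 4 (0.78 log units; beyond the scatter), and in place of 4-(trifluoromethyl)phenyl at the same position it gives a 39-fold lower number from compound 1 to compound 4 (1.59 log units; beyond the scatter). The earlier step suggested that a carbon-only ring stands higher on this read-out than a ring holding one nitrogen, but compound 4 carries a carbon-only ring and still stands beyond the scatter below both compound 1 and compound 2, so ring type alone does not set the number at this position. No measurement shown here accounts for this fall.

The compounds shown leave open whether the low number of compound 4 follows the nitrile itself or the particular ring that carries it, as no other compound pairs a nitrile with a different ring and no plain phenyl ring stands alongside it. They also leave open how a methoxy group or a carboxylic acid in place of that nitrile would read in this assay.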